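This account rests on a few compounds, and the source may have more. Where it says the series, first, only, none or still open, it means among the compounds named here.

Compound 1 `CCOc1ccc(-n2nncc2CN2C(=O)C3(C(C#N)=C(N)Oc4c(N)cc5nc6ccccc6nc5c43)c3ccccc32)cc1`: > 50000 nM
Compound 2 `Cc1ccc(-n2nncc2CN2C(=O)C3(C(C#N)=C(N)Oc4c(N)cc5nc6ccccc6nc5c43)c3ccccc32)cc1Cl`: > 50000 nM

Both values measured in an ADME assay on HUVEC cells (Homo sapiens) for antiproliferative activity, read by MTT assay, with a stated time of 48 h (on this read-out lower numbers stand for stronger inhibition and higher numbers for weaker inhibition), are limits of the assay rather than numbers. For compound 1 the value > 50000 nM is such a limit. Among the compounds with values here, for compound 2 the value > 50000 nM is likewise a limit, so compound 2 stands at the edge of what this assay can report, alongside the one other value, which is also a limit. Within the data shown here, the single measured step, a step that the two limits leave unreadable from compound 1 to compound 2, cannot be read in size or direction, because of the limit of > 50000 nM in this assay, at which 2 of the 2 values shown sit. Compound 3 `Cc1ccc(Cl)cc1-n1nncc1CN1C(=O)C2(C(C#N)=C(N)Oc3c(N)cc4nc5ccccc5nc4c32)c2ccccc21` is not yet measured. It differs from compound 2 by 5-chloro-2-methylphenyl in place of 3-chloro-4-methylphenyl on an aromatic nitrogen. Among the measured compounds shown here, the only related step is the unreadable one, so no shift beyond the scatter can be expected in either direction. Compound 3 is therefore expected at 80000 nM, within 20000 nM to 300000 nM, most likely reported again as a limit. The step that the limit leaves unreadable from compound 2 to compound 3 is thus estimated to be negligible.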

Compound 3, half-maximal inhibitory concentration: > 50000 nM
Compound 3 was reported as a limit; the forecaster's own chance of this, stated with the estimate: 85%; the middle value does not contradict the limit.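

The steps among compound 1, compound 2 and compound 3 cannot be read in size or direction, because all three values are limits: the limit of > 50000 nM in this assay, at which 3 of the 3 values shown sit.
The compounds shown leave open how far each lies from that limit, and whether changing the group on the aromatic nitrogen matters in this assay at all.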